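Adding a Methoxy Group to an Already Weak Inhibitor

The source may hold more compounds than are shown below. What is called first, only, known or untested is meant among the compounds shown, and "the series" means these compounds.

Compound 1 `CN1C(=O)N(C)C2C1NC(=S)N2/N=C/C=C/c1ccccc1` and compound 2 `CC(/C=N/N1C(=S)NC2C1N(C)C(=O)N2C)=C\c1ccccc1` share one core. In a functional assay on A549 cells (Homo sapiens) for inhibition, read by MTT assay, with a stated time of 72 h (on this read-out higher numbers stand for weaker inhibition and lower numbers for stronger inhibition), compound 1 gives 45700 nM and compound 2 gives 49400 nM; the step of a 1.1-fold higher number from compound 1 to compound 2 (0.03 log units; within the scatter) lies within the scatter. Compound 3 `CN1C(=O)N(c2ccccc2)C2NC(=S)N(/N=C/C=C/c3ccccc3)C21` carries a phenyl in place of the methyl on an amide-type nitrogen in the ring. For compound 3 this assay reports only a limit, > 100000 nM. The step of an at least 2.1-fold higher number from compound 1 to compound 3 (0.34 log units; beyond the scatter) therefore weakens inhibition, resting on (the limit of > 100000 nM in this assay, at which 1 of the 3 values shown sits).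

Compound 4 `COc1ccccc1/C=C/C=N/N1C(=S)NC2C1N(C)C(=O)N2c1ccccc1` differs from compound 3 by methoxy in place of hydrogen on an aromatic carbon. Among the compounds with values here, neither measured step touches this aromatic ring, so no measured step bears directly on it. Compound 4 is therefore expected to stay at the limit, with an estimated value of 150000 nM and a range from 50000 nM to 500000 nM. The expected step that the limit leaves unreadable from compound 3 to compound 4 is within the scatter.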

Compound 4, half-maximal inhibitory concentration: > 100000 nM
Compound 4 was reported as a limit (the forecaster's own chance of this, stated with the estimate: 75%); the middle value lies beyond the limit too.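

Compound 3 and compound 4 are both reported only as limits, so no step between them can be read: the limit of > 100000 nM in this assay, at which 2 of the 4 values shown sit.

The compounds shown leave open whether methoxy in place of hydrogen on this aromatic ring changes inhibition at all in this assay.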